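The source may hold more compounds than are shown below. What is called first, only, known or untested is meant among the compounds shown, and "the series" means these compounds.

Working notes on the series. The starting point is compound 1 `c1ccc(-c2ccc(Cn3cncc3CNc3cccc(-c4ccccc4)c3)cc2)cc1`, which in a toxicity assay on NIH3T3 cells (Mus musculus) for cytotoxicity, read by resazurin assay (a higher number here means that more compound is needed for the effect, a lower number that less compound is needed), gives 10000 nM. Compound 3 `O=[N+]([O-])c1ccc(Cn2cncc2CNc2cccc(-c3ccccc3)c2)cc1` carries nitro in place of phenyl on an aromatic carbon and gives 10000 nM in this assay; the step of no change at the digits printed from compound 1 to compound 3 (within the scatter). Compound 2 `Cc1cccc(-c2cccc(NCc3cncn3Cc3ccccc3)c2)c1C` shows in this assay only a limit of > 1000 nM, which is the limit of > 1000 nM in this assay, at which 1 of the 3 values shown sits. The next compound, compound 4 `CC(C)OC(=O)c1ccc(NCc2cncn2Cc2ccc(-c3ccccc3)cc2)cc1-c1ccccc1`, differs from compound 1 in that (isopropoxycarbonyl in place of hydrogen on an aromatic carbon). Within the data shown here, the single measured step stayed within the scatter, and no measured step covers an added group at this place, so no change beyond the scatter is expected here. For compound 4 in this assay the estimate is 10000 nM, with a range from 3000 nM to 30000 nM. That estimate means an expected step of no change at the digits printed from compound 1 to compound 4 (within the scatter), within the scatter.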

Compound 4, half-maximal effective concentration: > 10000 nM
Compound 4: a limit, no number (the forecaster's own chance of this, stated with the estimate: 30%); the middle value lies on the limit itself.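

At the aromatic carbon ortho to a phenyl group, isopropoxycarbonyl in place of hydrogen gives, in this assay, a number no lower from compound 1 to compound 4 (the limit leaves the size open). Among these compounds, the earlier step lay at a different place, so this is the first reading here, and the six added heavy atoms do not lower the concentration needed for the effect. For compound 4 the result is a limit, not a number: the limit of > 10000 nM in this assay, at which 1 of the 4 values shown sits.

From the compounds shown here alone, how far compound 4 lies beyond that limit stays open. So does the effect of a carboxylic acid or an amine at this place.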